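A few compounds are considered here, and "the series" means these few. Any claim that something is new, unique, unknown or untested is made for them only; others in the source may bear on it.

Compound 1 `O=C(/C=C/c1ccc(C(F)(F)F)cc1F)NO`: 14000 nM
Compound 2 `O=C(/C=C/c1c(F)cc(C(F)(F)F)cc1F)NO`: 12000 nM

In an ADME assay on Huh-7 cells (Homo sapiens) for inhibition, with a stated time of 3 days (on this read-out higher numbers stand for lower toxicity in this test and lower numbers for higher toxicity in this test), compound 1 stands within the scatter of compound 2, so the two numbers do not separate. Compound 3 `O=C(/C=C/c1ccc(C(F)(F)F)cc1Cl)NO` departs from compound 1 by chloro in place of fluoro on an aromatic carbon. Within the data shown here, the only measured step on this ring is a 1.2-fold lower number from compound 1 to compound 2 (0.07 log units; within the scatter). Among the measured compounds shown here, it is a different change, so it offers only indirect guidance, and no measured compound carries chloro. With that single small step as a guide, no shift beyond the scatter is expected. The expected step is a 1.2-fold lower number from compound 1 to compound 3 (0.07 log units; within the scatter). Compound 3 is estimated at 12000 nM, within a range of 5500 nM to 26000 nM.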

Compound 3, half-maximal cytotoxic concentration: 15000 nM
For compound 3 the middle estimate is 1.3-fold (0.10 log units) below the measured one; measured number inside the range.
By their numbers in this assay, from the lowest: compounds 2, 1 and 3 (each within the scatter of the next).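

In this assay, chloro in place of fluoro on the aromatic carbon ortho to a group of 6 heavy atoms and meta to a trifluoromethyl group gives a 1.1-fold higher number from compound 1 to compound 3 (0.03 log units; within the scatter) and so does not separate the two halogens at this position. Among these compounds, the earlier pair spoke only to fluoro in place of hydrogen, so this is the first sign that the halogen itself can be exchanged here without a shift beyond the scatter. No measured property bears on this result.

On these data alone, whether an amine, a methoxy group or a carboxylic acid on this carbon would move the number beyond the scatter remains open. So does whether chloro would behave the same way with the trifluoromethyl group replaced by another group.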